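Removing the Chloro Group From a Weaker Series Member

The source may report more compounds than this note shows. Statements on the series, on what has been measured and on what is new or still open speak of the compounds shown alone.

Three compounds sharing one core were tested in a functional assay on the whole organism (strain Swiss) with Mus musculus as the target, in the maximal electroshock model, with a stated time of 0.5 h, at a dose of 300 mg/kg by the intraperitoneal route; a lower number here means a weaker effect, a higher number a stronger effect of the compound at the dose given. Compound 1 `CC(C(=O)N1CCN(c2ccccc2)CC1)N1C(=O)CCC1=O` gives 50%. Compound 2 `CC(C(=O)N1CCN(c2ccc(Cl)cc2)CC1)N1C(=O)CCC1=O` gives 100%. Compound 3 `CCC(C(=O)N1CCN(c2ccc(Cl)cc2)CC1)N1C(=O)CCC1=O` gives 0%, the lowest of the three.

Compound 2 and compound 1 differ by hydrogen in place of chloro on an aromatic carbon, and this change gave a number 50 percentage points lower from compound 2 to compound 1 (beyond the scatter). The cores of compound 2 and compound 3 differ by methyl in place of hydrogen on a saturated chain carbon, two bonds along the chain from an amide-type nitrogen in a ring and a carbonyl carbon, which gave a number 100 percentage points lower from compound 2 to compound 3 (beyond the scatter).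

Compound 4 `CCC(C(=O)N1CCN(c2ccccc2)CC1)N1C(=O)CCC1=O` has not yet been measured in this assay. It differs from compound 3 by hydrogen in place of chloro on an aromatic carbon. The place of this change is the same as for the earlier pair, so it is the same change applied to the core of compound 3 instead of the core of compound 2.

From compound 3 to compound 4 the step is expected to be no change at the digits printed from compound 3 to compound 4 (within the scatter), smaller than the earlier one, because compound 3 already sits at 0% and the read-out cannot fall further. Compound 4 is estimated to give 0%, within 0% and 20%.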

Compound 4, a percentage reported as activity, at one dose (the size of the read-out at that dose, not a potency): 75%
Beside the measured number, compound 4's estimate is 75 percentage points below it, and the stated range ends below it.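

In this assay, putting hydrogen in place of chloro did not carry over from one core to the other; it gave a number 75 percentage points higher from compound 3 to compound 4 (beyond the scatter), a rise where the same change on the other core had given a fall: the same change on two cores in this assay, a number 50 percentage points lower (beyond the scatter) from compound 2 to compound 1 and a number 75 percentage points higher (beyond the scatter) from compound 3 to compound 4, 125 percentage points apart, beyond the scatter of two such steps

The methyl in place of hydrogen on the saturated chain carbon was just as dependent on its surroundings, giving a number 25 percentage points higher from compound 1 to compound 4 (beyond the scatter), a rise where the same change on the chloro-bearing core had given a fall: the same change on two cores in this assay, a number 100 percentage points lower (beyond the scatter) from compound 2 to compound 3 and a number 25 percentage points higher (beyond the scatter) from compound 1 to compound 4, 125 percentage points apart, beyond the scatter of two such steps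

This shows that, among these compounds, the effect of each change depends on the other, so a step seen on one core cannot simply be added on another; it does not show why, and with each change seen on only two cores and at one dose, it gives no rule for the wider series.

The compounds shown leave open how a fluoro or a methoxy group in place of chloro would behave on these cores. They also leave open what a longer chain on the same saturated chain carbon would do, with or without chloro.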